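A few compounds are considered here, and "the series" means these few. Any claim that something is new, unique, unknown or untested is made for them only; others in the source may bear on it.

Of the compounds shown here, three have so far been measured in a functional assay on HCT-116 cells (Homo sapiens) for inhibition, read by MTT assay, with a stated time of 72 h; on this read-out lower numbers stand for stronger inhibition of growth and higher numbers for weaker inhibition of growth. Compound 1 `CC1=C(CCCCCCCCCCn2cc(C[C@H](O)COCCOC[C@@H](O)Cc3ccc(-c4ccccc4)cc3)nn2)C(=O)c2ccccc2C1=O` gives 3000 nM in this assay, and compound 3 `COC1=C(OC)C(=O)C(CCCCCCn2cc(C[C@H](O)COCCOC[C@@H](O)Cc3ccc(-c4ccccc4)cc3)nn2)=C(C)C1=O` gives 5000 nM. Compound 2 `O[C@H](COCCOC[C@@H](O)Cc1cn(-c2ccc3c(c2)OCCO3)nn1)Cc1ccc(-c2ccccc2)cc1`, which carries a 2,3-dihydro-1,4-benzodioxin-6-yl group on an aromatic nitrogen of the shared core, gives 16500 nM in this assay. That is the highest of the three numbers, so compound 2 inhibits growth least strongly of the three; its gap to compound 3 and its larger gap to compound 1 both lie beyond the usual scatter of repeated measurements.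

Compound 4 `O[C@H](COCCOC[C@@H](O)Cc1cn(-c2cccnc2)nn1)Cc1ccc(-c2ccccc2)cc1` has not yet been measured. It differs from compound 2 in one place: pyridin-3-yl in place of 2,3-dihydro-1,4-benzodioxin-6-yl on an aromatic nitrogen. For the measured compounds named here, no measured pair shows this kind of swap, so there is no measured step to lean on. Both groups are aromatic rings set on the same aromatic nitrogen, and the measured compounds give no reason to expect the number to move far in either direction. The step expected from this change is a 1.2-fold higher number from compound 2 to compound 4 (0.08 log units; within the scatter), that is, nothing beyond the scatter. Compound 4 is therefore estimated to give 20000 nM in this assay, with a likely range from 8000 nM to 50000 nM.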

Compound 4, concentration for 50% growth inhibition: 46800 nM
For compound 4 the middle estimate is 2.3-fold (0.37 log units) below the measured one; measured number inside the range.
By their numbers in this assay, from the lowest: compounds 1 and 3 (each within the scatter of the next); then compound 2; then compound 4.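

For the compounds shown here, this is the first measured step at this position, the aromatic nitrogen of the five-membered ring. In this assay the swap of 2,3-dihydro-1,4-benzodioxin-6-yl for pyridin-3-yl gives a 2.8-fold higher number from compound 2 to compound 4 (0.45 log units; beyond the scatter), so the choice of aromatic ring here does change the read-out, and the entering group goes with weaker inhibition of growth. Nothing available here accounts for this step, and one pair of compounds sets no general rule.

The change replaces a larger group, made of an aromatic ring joined to a non-aromatic ring, with a single aromatic ring that holds a ring nitrogen, so the ring size and the ring nitrogen cannot be told apart on this pair alone. A plain phenyl ring on the same nitrogen would help to separate the two, and a 4-methoxyphenyl or a 4-aminophenyl group would show whether the number tracks a single oxygen or nitrogen substituent on that ring rather than the second ring as a whole.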